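The compounds below may be only part of what the source reports. "The series", "measured", "known", "first", "only" and "open" are said of these compounds alone.

Compound 1 `COc1ccc(C(=O)Nc2ccc(O)c3c(=O)cc(-c4ccccc4Cl)oc23)cc1` gives 5000 nM in the measurements so far
Compound 2 `O=c1cc(-c2ccccc2Cl)oc2c(N3CCCCC3)ccc(O)c12` gives 5700 nM in the measurements so far
Compound 3 `CCC(C)OC(=O)Nc1ccc(O)c2c(=O)cc(-c3ccccc3Cl)oc12` gives 18000 nM in the measurements so far

In a functional assay on ID8 cells (Mus musculus) for antiproliferative activity (a higher number here means a weaker inhibitor, a lower number a stronger inhibitor), compound 3 has the highest number of the three, and both other compounds lie beyond the scatter from it. Compound 4 `CS(=O)(=O)Nc1ccc(O)c2c(=O)cc(-c3ccccc3Cl)oc12` differs from compound 3 in one place, with methylsulfonyl in place of sec-butoxycarbonyl on a nitrogen on an aromatic ring in its structure.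

Among the measured compounds shown here, two measured steps bear on this change. One is a 3.6-fold higher number from compound 1 to compound 3 (0.56 log units; beyond the scatter) with sec-butoxy in place of 4-methoxyphenyl on a carbonyl carbon. The other is a 3.2-fold higher number from compound 2 to compound 3 (0.50 log units; beyond the scatter) with (sec-butoxycarbonyl)amino in place of piperidin-1-yl on an aromatic carbon. Both are modest, and in both the compound carrying sec-butoxycarbonyl has the higher number. For the measured compounds named here, no measured compound carries methylsulfonyl, so this is weak guidance from only three compounds.

A modest move to a lower number is therefore expected, and the estimated step is a 2.3-fold lower number from compound 3 to compound 4 (0.35 log units; beyond the scatter) at this stage. In this assay the estimate for compound 4 is 8000 nM within an expected range of 2500 nM to 22000 nM for now.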

Compound 4, half-maximal inhibitory concentration: 16000 nM
Beside the measured number, compound 4's estimate is 2.0-fold (0.30 log units) below it, and the stated range covers the measured number.
By their numbers in this assay, from the lowest: compounds 1 and 2 (each within the scatter of the next); then compounds 4 and 3 (each within the scatter of the next).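

In this assay, replacing sec-butoxycarbonyl with methylsulfonyl on the nitrogen gives a 1.1-fold lower number from compound 3 to compound 4 (0.05 log units; within the scatter), so this assay does not separate the two groups, even though methylsulfonyl has fewer heavy atoms and a different central atom. The gaps to the other two compounds also persist with this new group, with a 2.8-fold higher number from compound 2 to compound 4 (0.45 log units; beyond the scatter) and a 3.2-fold higher number from compound 1 to compound 4 (0.51 log units; beyond the scatter), so the higher numbers are not confined to sec-butoxycarbonyl. No measurement here offers an explanation for these steps.

From the compounds shown here alone, it remains open whether a free amino group or a small acetyl group on this nitrogen would give a number closer to that of compound 1 or to that of compound 3. A longer chain on the sulfonyl group is also an open case, since methylsulfonyl is the only sulfonyl group shown.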